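Methoxy Removal on a Pendant Ring: Expectation for Compound 4

The source may report more compounds than this note shows. Statements on the series, on what has been measured and on what is new or still open speak of the compounds shown alone.

Compound 1 `COC(=O)c1c(-c2ccc([N+](=O)[O-])cc2)oc2ccccc2c1=O` and compound 2 `COC(=O)c1c(-c2ccc([N+](=O)[O-])cc2)oc2cc(OC)ccc2c1=O` share a core that differs from that of compound 3 `COc1cc(-c2oc3ccccc3c(=O)c2C(=O)O)cc(OC)c1OC` in a way not broken down here. In a functional assay on SK-MEL cells (Homo sapiens) for cytotoxicity, read by MTT assay, with a stated time of 6 days (a lower number here means that less compound is needed, a higher number that more compound is needed for the effect), compound 2 gives 2.84 ug/mL. Compound 1 reaches only a limit, > 25 ug/mL, in this assay. The change hydrogen in place of methoxy on an aromatic carbon thus produces an at least 8.8-fold higher number from compound 2 to compound 1 (0.94 log units; beyond the scatter). Compound 3 likewise sits at a limit, > 25 ug/mL, in this assay. Compound 4 `COc1cc(OC)cc(-c2oc3ccccc3c(=O)c2C(=O)O)c1` carries the same kind of change, (hydrogen in place of methoxy on an aromatic carbon), but the place differs: here the carbon is ortho to two methoxy groups and para to a large group, rather than part of a fused system meta and para to a fused ring. Because compound 3 already stands at the limit of > 25 ug/mL in this assay, at which 2 of the 3 values shown sit, compound 4 is expected to remain there as well. The step that the limit leaves unreadable from compound 3 to compound 4 is estimated to be small in this assay. Compound 4 is therefore estimated at 40 ug/mL, between 15 ug/mL and 100 ug/mL.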

Compound 4, concentration for half-maximal effect: > 25 ug/mL
Compound 4 was reported as a limit; the forecaster's own chance of this, stated with the estimate: 80%; the middle value does not contradict the limit.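

Compound 3 and compound 4 both stand at a limit, so the step between them cannot be read: the limit of > 25 ug/mL in this assay, at which 3 of the 4 values shown sit.

The compounds shown leave open whether hydrogen in place of methoxy at this place changes the number at all in this assay.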